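The compounds below may be only part of what the source reports. "The series", "measured", "known", "first", "only" and "open" are said of these compounds alone.

Measured compounds:
Compound 2 `Cc1cccc(S(=O)(=O)Nc2ccc(N3CCN(c4cccc(-c5c(C(=O)NCCCN6CCN(C)CC6)c(C)n(C)c5-c5ccc(Cl)cc5)c4)CC3)cc2)c1`: 178 nM
Compound 1 `Cc1c(C(=O)NCCCN2CCN(C)CC2)c(-c2cccc(N3CCN(c4ccc(NS(=O)(=O)c5cccc(OC(C)C)c5)cc4)CC3)c2)c(-c2ccc(Cl)cc2)n1C`: 522 nM

For the measured compounds named here, compound 2 gives the lower of the two numbers in an assay for binding affinity to Apoptosis regulator Bcl-2 (Homo sapiens), read by fluorescence polarization, with a stated time of 2 h (on this read-out lower numbers stand for stronger inhibition and higher numbers for weaker inhibition), and the one measured step, a 2.9-fold lower number from compound 1 to compound 2 (0.47 log units; beyond the scatter), lies beyond the scatter. Compound 3 `COc1cccc(S(=O)(=O)Nc2ccc(N3CCN(c4cccc(-c5c(C(=O)NCCCN6CCN(C)CC6)c(C)n(C)c5-c5ccc(Cl)cc5)c4)CC3)cc2)c1` differs from compound 2 by methoxy in place of methyl on an aromatic carbon. Going by the values given here, the step from compound 1 to compound 2 bears on this change only in part: it removed an oxygen-linked group from this ring and brought in methyl, whereas compound 3 brings an oxygen-linked group back, though not the one compound 1 carried. Among the compounds with values here, no step with methoxy itself has been measured, so the direction rests on that single comparison. The step is therefore expected to be small, if anything toward a higher number, a 1.5-fold higher number from compound 2 to compound 3 (0.16 log units; within the scatter). Compound 3 is expected to give 260 nM in this assay, with a range from 100 nM to 650 nM.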

Compound 3, inhibition constant: 207 nM
Estimate against measurement, compound 3: 1.3-fold (0.10 log units) above, and the stated range covers the measured number.
By their numbers in this assay, from the lowest: compounds 2 and 3 (each within the scatter of the next); then compound 1.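

In this assay, the step of a 1.2-fold higher number from compound 2 to compound 3 (0.07 log units; within the scatter) lies within the scatter, so methyl and methoxy on this aromatic carbon, meta to a large group, cannot be told apart. An oxygen on this ring therefore does not by itself go with the higher number of compound 1: with the oxygen kept, methyl in place of isopropyl on that oxygen gives a 2.5-fold lower number from compound 1 to compound 3 (0.40 log units; beyond the scatter), a modest step beyond the scatter, and this places the difference in the group carried on the oxygen. Nothing available here accounts for either result.

The compounds shown leave open how ethoxy would read at this place, and so whether the number rises gradually or abruptly as the group on the oxygen grows from methyl to isopropyl. Also open, on these data alone, is how an amine or a carboxylic acid on this carbon would compare with methyl and methoxy.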